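The source may report more compounds than this note shows. Statements on the series, on what has been measured and on what is new or still open speak of the compounds shown alone.

In an in vivo ADME assay on the whole organism (strain BALB/c) for pharmacokinetics, with Mus musculus as the target, read by LC-MS, at a dose of 5 mg/kg by the oral route (a higher number here means faster removal of the compound, a lower number slower removal), three compounds have been measured so far:
compound 1 `CC(C)c1ccc(S(C)(=O)=O)cc1C#Cc1cc(C#N)ccc1OCC(=O)O` gives 145 mL/min/kg
compound 2 `CN(C)S(=O)(=O)c1ccc(F)c(C#Cc2cc(Cl)ccc2OCC(=O)O)c1` gives 10 mL/min/kg
compound 3 `CC(C)c1ccc(S(C)(=O)=O)cc1C#Cc1cc(Cl)ccc1OCC(=O)O` gives 8.33 mL/min/kg

Compound 3 sits at the low end of this small set, within the scatter of compound 2, while compound 1 stands far higher. The next compound, compound 4 `CS(=O)(=O)c1ccc(F)c(C#Cc2cc(Cl)ccc2OCC(=O)O)c1`, departs from compound 3 in one place (fluoro in place of isopropyl on an aromatic carbon): fluoro in place of isopropyl on an aromatic carbon, ortho to a large group and para to a methylsulfonyl group.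

Going by the values given here, only one measured step links compounds that differ in a single place. It runs a 17-fold lower number from compound 1 to compound 3 (1.24 log units; beyond the scatter), a large step with chloro in place of cyano on an aromatic carbon. Compound 4 keeps that chloro, so this step says little directly about the new change. The closest guide is compound 2, which also carries a fluoro group and gives 10 mL/min/kg in this assay, close to compound 3. No step beyond the scatter is therefore expected, with at most a slight rise. The estimated change is a 1.4-fold higher number from compound 3 to compound 4 (0.16 log units; within the scatter) in size. For compound 4 the expected clearance is about 12 mL/min/kg, with an estimated range from 5 mL/min/kg to 30 mL/min/kg as the likely span.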

Compound 4, clearance: 6.67 mL/min/kg
Compound 4: middle estimate off by 1.8-fold (0.26 log units), on the high side; the range from low to high includes it.
By their numbers in this assay, from the lowest: compounds 4, 3 and 2 (each within the scatter of the next); then compound 1.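

In this assay, fluoro in place of isopropyl on this aromatic carbon, ortho to a large group and para to a methylsulfonyl group, gives a 1.2-fold lower number from compound 3 to compound 4 (0.10 log units; within the scatter), so this exchange of a branched group for a single atom produces no step beyond the scatter in the chloro series. Going by these compounds alone, the sulfonyl sulfur can now be read as well: methyl in place of dimethylamino gives a 1.5-fold lower number from compound 2 to compound 4 (0.18 log units; within the scatter), so both changes stand apart from the only step beyond the scatter so far, a 17-fold lower number from compound 1 to compound 3 (1.24 log units; beyond the scatter). Nothing shown here explains why these two changes leave the clearance within the scatter.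

The compounds shown leave open whether an amine, a methoxy group or a longer chain on the same aromatic carbon would also stay within the scatter of compound 3, and whether a cyclopropyl or ethyl group on the sulfonyl sulfur would stay within the scatter of compound 4. Within the data shown here, they also leave open whether fluoro in place of isopropyl would give a similar step alongside a nitrile, as compound 1 is the only nitrile-bearing compound among them.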